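Shifting a methoxy group on the aryl piperazine

A few compounds are considered here, and "the series" means these few. Any claim that something is new, unique, unknown or untested is made for them only; others in the source may bear on it.

Three compounds share one core and are measured in an assay on HEK293 cells for inhibition of Voltage-dependent T-type calcium channel subunit alpha-1G (Homo sapiens), read by fluorescence, tested at 10 uM; a lower number here means less inhibition, a higher number more inhibition at the concentration tested (going by the name of the read-out). Compound 1 `CCCc1nc(-c2ccccc2)c(CNCCCN2CCN(c3ccccc3C(F)(F)F)CC2)o1` gives 45%, compound 2 `CCCc1nc(-c2ccccc2)c(CNCCN2CCN(c3cccc(OC)c3)CC2)o1` gives 40.2%, and compound 3 `CCCc1nc(-c2ccccc2)c(CNCCCN2CCN(c3ccc(C)c(C)c3)CC2)o1` gives 54.6%. Compound 2 lies close to compound 1, within the scatter, and beyond the scatter below compound 3. Compound 4 `CCCc1nc(-c2ccccc2)c(CNCCN2CCN(c3ccccc3OC)CC2)o1` differs from compound 2 by 2-methoxyphenyl in place of 3-methoxyphenyl on an amine nitrogen in a ring. Among the measured compounds shown here, the only measured step that touches the same place is the change of the aryl group on the ring nitrogen, a number 9.6 percentage points higher from compound 1 to compound 3 (within the scatter), which stayed within the scatter. A move from compound 2 to compound 4 is therefore expected to bring no step beyond the scatter, a number 3.8 percentage points higher from compound 2 to compound 4 (within the scatter). Compound 4 is estimated to give 44% in this assay, within 28% to 60%.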

Compound 4, a percentage reported as inhibition, at one concentration (the size of the read-out at that concentration, not a potency): 39.7%
For compound 4 the middle estimate is 4.3 percentage points above the measured one; the range from low to high includes it.
By their numbers in this assay, from the lowest: compounds 4, 2, 1 and 3 (each within the scatter of the next, the first and the last beyond it).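

Moving the methoxy group, with 2-methoxyphenyl in place of 3-methoxyphenyl on the ring nitrogen, gives a number 0.5 percentage points lower from compound 2 to compound 4 (within the scatter) in this assay. Unlike the earlier step, which exchanged one substituted aryl group for a different one, this change keeps the same atoms and alters only where the methoxy group sits, and the reading holds within the scatter. No measurement at hand offers an explanation for this result. On these data alone, it remains open whether an amine or a carboxylic acid in place of the methoxy group would read the same, and whether this move would read alike on the longer chain of compound 1 and compound 3.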